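A few compounds are considered here, and "the series" means these few. Any claim that something is new, unique, unknown or untested is made for them only; others in the source may bear on it.

Working notes on the series.

In an assay on isolated protein for binding affinity to Alpha-1D adrenergic receptor (Homo sapiens) (on this read-out lower numbers stand for stronger inhibition and higher numbers for weaker inhibition), compound 1 `COC(=O)C1=C(C)N=C(C)N(CCCCCN2CCC(c3ccccc3C(F)(F)F)CC2)C1c1ccc(F)c(F)c1` gives 1100 nM. Within the data shown here, compound 2 `COC(=O)C1=C(C)N=C(C)N(CCCCCN2CCC(c3ccccc3OC)CC2)C1c1ccc(F)c(F)c1` gives 120 nM in this assay, and the only single-point step measured so far, a 9.2-fold lower number from compound 1 to compound 2 (0.96 log units; beyond the scatter), is the one change that has been followed at the same aromatic carbon. Compound 3 `COC(=O)C1=C(C)N=C(C)N(CCCCCN2CCN(c3ccccc3OC)CC2)C1c1ccc(F)c(F)c1` gives 65 nM in this assay. Compound 3 has the lowest of the three numbers; its value and that of compound 2 lie within the scatter of each other, so no order between these two can be read, while compound 1 sits well apart from both.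

Compound 4 `COC(=O)C1=C(C)N=C(C)N(CCCCCN2CCN(c3ccccc3C(=O)OC)CC2)C1c1ccc(F)c(F)c1` has not yet been measured. It differs from compound 3 by methoxycarbonyl in place of methoxy on an aromatic carbon. Among the measured compounds shown here, no measured step covers this exchange: the step from compound 1 to compound 2 changed the group at a comparable aromatic carbon on a different saturated ring, and it brought methoxy in rather than taking it out. That step shows the position is sensitive, but it gives no direction for methoxycarbonyl. The expectation for compound 4 is therefore a step of a 2.3-fold higher number from compound 3 to compound 4 (0.36 log units; beyond the scatter) in this assay, leaning toward a somewhat higher number, with wide uncertainty. Compound 4 is estimated at 150 nM, expected between 40 nM and 600 nM.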

Compound 4, inhibition constant: 79 nM
Beside the measured number, compound 4's estimate is 1.9-fold (0.28 log units) above it; the measured number falls inside the stated range.
By their numbers in this assay, from the lowest: compounds 3, 4 and 2 (each within the scatter of the next); then compound 1.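

In this assay the exchange gives a 1.2-fold higher number from compound 3 to compound 4 (0.08 log units; within the scatter), so methoxy and methoxycarbonyl cannot be told apart at this aromatic carbon, even though methoxycarbonyl brings more heavy atoms and more hydrogen-bond acceptors. Compounds 1 and 2 had shown only that a change of group at a comparable aromatic carbon, on a different saturated ring, can matter, with a 9.2-fold lower number from compound 1 to compound 2 (0.96 log units; beyond the scatter); compounds 3 and 4 now show that not every exchange at such a carbon moves the number beyond the scatter, though this rests on these two pairs alone. No measurement at hand speaks to why methoxy and methoxycarbonyl read alike here.

The compounds shown leave open how far this tolerance extends on the ring shared by compound 3 and compound 4, for instance whether a carboxylic acid or an amine on the same aromatic carbon would stay within the scatter of methoxycarbonyl. They also leave open whether trifluoromethyl on that carbon of this ring would give a step like the one seen on the other saturated ring, and whether methoxycarbonyl would read the same there.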